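The compounds below may be only part of what the source reports. "The series", "measured", "known", "first", "only" and "open" are said of these compounds alone.

Compounds measured so far in a functional assay on BJAB cells (Homo sapiens) for antiproliferative activity, with a stated time of 4 days; on this read-out lower numbers stand for an effect already at smaller amounts and higher numbers for an effect only at larger amounts of compound:

Compound 1, `Cc1cc(C#N)cc(-c2c(C)nn(-c3nc(-c4ccc(Cl)c(Cl)c4)c(SC(C)C)s3)c2C(=O)O)c1`: 4800 nM
Compound 2, `Cc1nn(-c2nc(-c3ccc(Cl)c(Cl)c3)c(SC(C)C)s2)c(C(=O)O)c1-c1cnccn1`: 14000 nM
Compound 3, `Cc1cccc(-c2c(C)nn(-c3nc(-c4ccc(Cl)c(Cl)c4)c(SC(C)C)s3)c2C(=O)O)c1`: 17000 nM

Compound 3 gives the highest number of the three in this assay. Its nearest neighbour is compound 2; the two values lie within the scatter of each other, so no order between them can be read. The gap to compound 1 is larger: a 3.5-fold higher number from compound 1 to compound 3 (0.55 log units; beyond the scatter), a step that goes beyond the scatter.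

The unmeasured compound 4, `Cc1nn(-c2nc(-c3ccc(Cl)c(Cl)c3)c(SC(C)C)s2)c(C(=O)O)c1-c1ccncc1`, differs from compound 3 in one place: pyridin-4-yl in place of 3-methylphenyl on an aromatic carbon.

Among the compounds with values here, the step that bears most directly on this change is the one between compound 2 and compound 3, where one six-membered ring with two nitrogen atoms stood against a 3-methylphenyl group: a 1.2-fold higher number from compound 2 to compound 3 (0.08 log units; within the scatter), within the scatter. The other two steps, a 2.9-fold higher number from compound 1 to compound 2 (0.46 log units; beyond the scatter) and a 3.5-fold higher number from compound 1 to compound 3 (0.55 log units; beyond the scatter), concern the cyano-bearing ring of compound 1 and do not touch the pyridin-4-yl case. On this basis the expected step in this assay from compound 3 to compound 4 is small, a 1.1-fold lower number from compound 3 to compound 4 (0.05 log units; within the scatter), with no clear direction beyond the scatter. Compound 4 is therefore estimated at 15000 nM, in a range from 6000 nM to 40000 nM.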

Compound 4, half-maximal effective concentration: 5900 nM
For compound 4 the middle estimate is 2.5-fold (0.41 log units) above the measured one; measured number outside the range, below it.
By their numbers in this assay, from the lowest: compounds 1 and 4 (each within the scatter of the next); then compounds 2 and 3 (each within the scatter of the next).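

In this assay, pyrazin-2-yl and 3-methylphenyl had not separated at this position, but pyridin-4-yl separates from both, with a 2.9-fold lower number from compound 3 to compound 4 (0.46 log units; beyond the scatter) and a 2.4-fold lower number from compound 2 to compound 4 (0.38 log units; beyond the scatter). A ring nitrogen alone therefore does not set the number here, since compound 2 also carries ring nitrogen yet stays within the scatter of compound 3. Compound 4 also lies within the scatter of compound 1, with a 1.2-fold higher number from compound 1 to compound 4 (0.09 log units; within the scatter), so the unsubstituted pyridin-4-yl ring matches the 3-cyano-5-methylphenyl ring without carrying a nitrile.

Nothing available explains why pyridin-4-yl parts from pyrazin-2-yl. Going by these compounds, it remains open whether pyridin-3-yl or pyridin-2-yl, with the ring nitrogen elsewhere, would stay with compound 4, and whether a nitrile or an amine on the pyridin-4-yl ring would move the number further.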